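Series notes: amine-bearing ether chains on the shared core

A few compounds are considered here, and "the series" means these few. Any claim that something is new, unique, unknown or untested is made for them only; others in the source may bear on it.

Compound 1 `CC(C)=CCc1cc(C(=O)Nc2cc3ccc(OCC4CCCNC4)c(C)c3oc2=O)ccc1O` carries a piperidin-3-yl group on a saturated chain carbon bound to an oxygen on an aromatic ring. For the measured compounds named here, in a functional assay on MCF7 cells (Homo sapiens) for antiproliferative activity (a higher number here means a weaker inhibitor, a lower number a stronger inhibitor), compound 1 gives 790 nM, the lowest of the three numbers so far, though within the scatter of the other two. Compound 2 `CCCNCCCOc1ccc2cc(NC(=O)c3ccc(O)c(CC=C(C)C)c3)c(=O)oc2c1C` gives 980 nM and compound 3 `CC(C)=CCc1cc(C(=O)Nc2cc3ccc(OCCCNC(C)(C)C)c(C)c3oc2=O)ccc1O` gives 950 nM in this assay. The steps of a 1.2-fold higher number from compound 1 to compound 2 (0.09 log units; within the scatter) and a 1.2-fold higher number from compound 1 to compound 3 (0.08 log units; within the scatter) both exchange the piperidin-3-yl group for an open amine-bearing chain at the same place and both stay within the scatter; a 1.0-fold lower number from compound 2 to compound 3 (0.01 log units; within the scatter) shows that tert-butyl in place of propyl on the amine nitrogen also leaves the number unmoved.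

Compound 4 `CC(C)=CCc1cc(C(=O)Nc2cc3ccc(OCCCN[C@H](C)c4ccccc4)c(C)c3oc2=O)ccc1O` differs from compound 1 by 2-((1-phenylethyl)amino)ethyl in place of piperidin-3-yl on a saturated chain carbon bound to an oxygen on an aromatic ring. This again replaces the ring with an open amine-bearing chain at the same place, so no step beyond the scatter is expected, in line with the steps from compound 1 to compound 2 and compound 3. Compound 4 is therefore estimated at 900 nM in this assay, with a range of 400 nM to 2000 nM, which means an expected step of a 1.1-fold higher number from compound 1 to compound 4 (0.06 log units; within the scatter).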

Compound 4, half-maximal inhibitory concentration: 1450 nM
The estimate for compound 4 lay 1.6-fold (0.21 log units) below the measured number; the measured number falls inside the stated range.
By their numbers in this assay, from the lowest: compounds 1, 3, 2 and 4 (each within the scatter of the next).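

An aromatic ring is tolerated at this position: the open chain 3-((1-phenylethyl)amino)propyl stands in for (piperidin-3-yl)methyl with a 1.8-fold higher number from compound 1 to compound 4 (0.26 log units; within the scatter), so this larger group stays within the scatter in this assay. On the amine nitrogen, 1-phenylethyl also leaves the number within the scatter, both in place of tert-butyl, with a 1.5-fold higher number from compound 3 to compound 4 (0.18 log units; within the scatter), and in place of propyl, with a 1.5-fold higher number from compound 2 to compound 4 (0.17 log units; within the scatter), so the four compounds show no step beyond the scatter from a ring, a branched group or a straight chain here. No supporting data bear on these results.

From the compounds shown here alone, whether a carboxylic acid in place of the amine, or a longer chain between the oxygen and the nitrogen, would move the number remains open. Going by these compounds, the mirror-image form of the 1-phenylethyl group also remains open.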